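The source may hold more compounds than are shown below. What is called first, only, known or untested is meant among the compounds shown, and "the series" means these compounds.

Measured in a toxicity assay on the whole organism with Rattus norvegicus as the target, at a dose of 100 mg/kg by the oral route; on this read-out lower numbers stand for a weaker effect and higher numbers for a stronger effect at the one dose given:

Compound 1, `Clc1ccc(OCC2=NCCO2)cc1`: 30%
Compound 2, `Clc1ccccc1OCC1=NCCO1`: 20%
Compound 3, `Cc1ccc(OCC2=NCCO2)c(C)c1`: 25%

Of these three numbers, compound 2 shows the lowest. The gap to compound 3 and the gap to compound 1 both lie within the usual scatter of repeated measurements of this kind, so the three compounds cannot be told apart on this read-out; none of them can be called weaker or stronger than the others.

Compound 4, `Fc1ccccc1OCC1=NCCO1`, has not yet been measured. Compared with compound 2 it differs in a single place: fluoro in place of chloro on an aromatic carbon. Going by the values given here, no step between two measured compounds that differ in only one place is available, so there is nothing among the measured compounds that would point to a rise or a fall for this kind of change.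

The step from compound 2 to compound 4 is therefore expected to be no change at the digits printed from compound 2 to compound 4 (within the scatter), that is, no change beyond the scatter. Compound 4 is estimated at 20%, with a range from 5% to 40%.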

Compound 4, a percentage reported as activity, at one dose (the size of the read-out at that dose, not a potency): 40%
Estimate against measurement, compound 4: 20 percentage points below; measured number inside the range.
By their numbers in this assay, from the lowest: compounds 2, 3, 1 and 4 (each within the scatter of the next, the first and the last beyond it).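

Fluoro in place of chloro on this aromatic carbon, ortho to a group of 7 heavy atoms, gives a number 20 percentage points higher from compound 2 to compound 4 (beyond the scatter) in this assay, the only step here that changes a single place. This position therefore responds to the choice of halogen, even though the two groups count the same in heavy atoms and neither brings a hydrogen-bond donor or acceptor. Nothing available explains why the number moves.

As far as these compounds go, with one step at one position, it remains open whether the same exchange would act alike on another carbon of the ring, as in the chloro group of compound 1. From the compounds shown here alone, it is also open how a methoxy group, an amine or plain hydrogen on this carbon would compare with either halogen.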